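Trifluoromethoxy Added to the Sulfonyl-Bearing Ring

The compounds below may be only part of what the source reports. "The series", "measured", "known", "first", "only" and "open" are said of these compounds alone.

For the measured compounds named here, compound 3 `O=C(NCc1cnco1)Nc1ccc(S(=O)(=O)c2ccccc2)cc1` stands second highest of the three numbers measured so far: in an assay on isolated protein for activation of Nicotinamide phosphoribosyltransferase (Homo sapiens) (a higher number here means that more compound is needed for the effect, a lower number that less compound is needed), compound 3 gives 77 nM. Compound 2 `O=C(NCc1cn[nH]c1)Nc1ccc(S(=O)(=O)c2ccccc2)cc1` gives 28 nM, and the step of a 2.8-fold higher number from compound 2 to compound 3 (0.44 log units; beyond the scatter) lies beyond the scatter. Compound 1 `O=C(NCc1ccncc1)Nc1ccc(S(=O)(=O)c2ccccc2Cl)cc1` gives 79 nM, a value within the scatter of that of compound 3. Compound 4 `O=C(NCc1cnco1)Nc1ccc(S(=O)(=O)c2cccc(OC(F)(F)F)c2)cc1` differs from compound 3 by trifluoromethoxy in place of hydrogen on an aromatic carbon. Going by the values given here, no measured step bears directly on this change: compound 1 differs from compound 3 in two places at once, so its value does not isolate a substituent on that ring, and the one measured step, from compound 2 to compound 3, concerns the heteroaryl end of the molecule. With nothing to point either way, compound 4 is expected to stay close to compound 3, with an estimated step of a 1.2-fold lower number from compound 3 to compound 4 (0.07 log units; within the scatter) that falls within the usual scatter. Compound 4 is therefore estimated at 65 nM, with a range from 20 nM to 200 nM.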

Compound 4, half-maximal effective concentration: 70 nM
Beside the measured number, compound 4's estimate is 1.1-fold (0.03 log units) below it, within the range that was stated.
By their numbers in this assay, from the lowest: compound 2; then compounds 4, 3 and 1 (each within the scatter of the next).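

In this assay, the step of a 1.1-fold lower number from compound 3 to compound 4 (0.04 log units; within the scatter) lies within the scatter, so trifluoromethoxy, with its 5 heavy atoms, takes the place of hydrogen on this aromatic carbon, meta to a large group, without a readable change in the number. For the compounds shown here, this is the first single-place comparison on this ring, since the earlier step concerned only the heteroaryl end of the molecule. Nothing available explains why the number holds steady.

On these data alone, whether a carboxylic acid or an amine on the same carbon would leave the number equally unmoved remains open, as does the effect of trifluoromethoxy on other carbons of this ring. As far as these compounds go, it is also open whether the same group would leave the value of compound 2, with its 1H-pyrazol-4-yl end, in place.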